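The compounds below may be only part of what the source reports. "The series", "measured", "known", "first", "only" and "open" are said of these compounds alone.

Measured so far:
compound 1 `CCCCCCCCCCCC(=O)OC[C@H](CSC[C@@H](N)C(=O)NC1(CO)CC1)OC(=O)CCCCCCCCCCC` — 265 nM
compound 2 `CCCCCCCCCCCC(=O)OC[C@H](CSC[C@@H](N)C(=O)NC(C)c1ccccc1)OC(=O)CCCCCCCCCCC` — 9900 nM

Both numbers come from an assay on HEK293 cells for agonist activity at Toll-like receptor 2 (Homo sapiens); on this read-out higher numbers stand for an effect only at larger amounts of compound and lower numbers for an effect already at smaller amounts. Within the data shown here, compound 2 stands at the higher of the two, and the only step recorded so far is the one leading to it: a 37-fold higher number from compound 1 to compound 2 (1.57 log units; beyond the scatter). That step swaps the whole group on the amide-type nitrogen, so it says nothing direct about what happens when only the aromatic part of the group is changed.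

Compound 3 `CCCCCCCCCCCC(=O)OC[C@H](CSC[C@@H](N)C(=O)NC(C)CCc1ccccc1)OC(=O)CCCCCCCCCCC` differs from compound 2 by one change: phenethyl in place of phenyl on a saturated chain carbon bound to an amide-type nitrogen and a saturated chain carbon. Among the measured compounds shown here, no measured pair shows this kind of change, so there is no step to lean on; the only guide is that compound 2 itself already sits far from compound 1. With nothing pointing in either direction, the expectation is a number near that of compound 2, with a step of a 1.2-fold lower number from compound 2 to compound 3 (0.09 log units; within the scatter) that may well stay within the scatter. Compound 3 is therefore estimated at 8000 nM, with a range from 2000 nM to 30000 nM.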

Compound 3, half-maximal effective concentration: 160 nM
For compound 3 the middle estimate is 50-fold (1.70 log units) above the measured one; the measured number lies below the stated range.
By their numbers in this assay, from the lowest: compounds 3 and 1 (each within the scatter of the next); then compound 2.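

In this assay, phenethyl in place of phenyl on a saturated chain carbon bound to an amide-type nitrogen and a saturated chain carbon gives a 62-fold lower number from compound 2 to compound 3 (1.79 log units; beyond the scatter), which shows that this position responds strongly to the length of the link carrying the aromatic ring, even though the ring itself stays the same. The earlier step could not show this, as it replaced the whole group on the amide-type nitrogen, whereas a 1.7-fold lower number from compound 1 to compound 3 (0.22 log units; within the scatter) now shows that a group with an aromatic ring, 1-methyl-3-phenylpropyl, cannot be told apart from 1-(hydroxymethyl)cyclopropyl, so among these compounds the aromatic ring does not by itself go with the high number seen for compound 2. No measurement shown here explains why this small change in the group has so large an effect.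

Going by these compounds, it remains open whether a still longer link, as in a phenylpropyl group on the same carbon, would keep the number low or raise it again. Also open, on these data alone, is how a hydroxyl or an amine on the aromatic ring, or a hydrogen in place of the methyl group, would change the result.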